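Swapping a hydroxybutyl chain for an aminocyclohexyl ring

This account rests on a few compounds, and the source may have more. Where it says the series, first, only, none or still open, it means among the compounds named here.

Compound 1 `CCC(O)CSc1nc(NCc2ccc(-c3ccccn3)cc2)c2[nH]nc(C(C)C)c2n1` gives 273 nM in a functional assay on HT cells (Homo sapiens) for antiproliferative activity, read by fluorescence, with a stated time of 72 h (a lower number here means a stronger inhibitor of growth, a higher number a weaker inhibitor of growth), the second highest of the three numbers measured here. Compound 2 `CC(C)c1n[nH]c2c(NCc3ccc(-c4ccccn4)cc3)nc(SCCn3ccnc3)nc12` gives 155 nM, and compound 3 `CC(C)c1n[nH]c2c(NCc3ccc(-c4ccccn4)cc3)nc(SC(CO)C(C)C)nc12` gives 980 nM. The step of a 1.8-fold lower number from compound 1 to compound 2 (0.25 log units; within the scatter) stays within the scatter, while a 3.6-fold higher number from compound 1 to compound 3 (0.56 log units; beyond the scatter) and a 6.3-fold higher number from compound 2 to compound 3 (0.80 log units; beyond the scatter) show that the branched hydroxy group weakens inhibition somewhat.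

Compound 4 `CC(C)c1n[nH]c2c(NCc3ccc(-c4ccccn4)cc3)nc(SC3CCCCC3N)nc12` differs from compound 1 by 2-aminocyclohexyl in place of 2-hydroxybutyl on a sulfur. For the measured compounds named here, none of the measured steps exchanges the chain for a ring bearing an amine, so the only guide is that changes on this sulfur substituent have so far moved the number modestly in either direction. A modest step is therefore expected, most likely a 1.2-fold higher number from compound 1 to compound 4 (0.07 log units; within the scatter), giving an estimated 320 nM for compound 4, with a range from 120 nM to 850 nM.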

Compound 4, concentration for 50% growth inhibition: 139 nM
The estimate for compound 4 lay 2.3-fold (0.36 log units) above the measured number; the range from low to high includes it.
By their numbers in this assay, from the lowest: compounds 4, 2 and 1 (each within the scatter of the next); then compound 3.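

On this sulfur, a ring bearing an amine keeps the growth inhibition seen with the open chains: in this assay 2-aminocyclohexyl gives a 2.0-fold lower number from compound 1 to compound 4 (0.29 log units; within the scatter) and a 1.1-fold lower number from compound 2 to compound 4 (0.05 log units; within the scatter) and so cannot be told apart from 2-hydroxybutyl or 2-(1H-imidazol-1-yl)ethyl. Against the branched 1-(hydroxymethyl)-2-methylpropyl group, it gives a 7.1-fold lower number from compound 3 to compound 4 (0.85 log units; beyond the scatter) and this gap is beyond the scatter. No measurement here explains these numbers. Still open, as far as these compounds go, is how a plain cyclohexyl ring without the amine would compare on this sulfur, which would separate the part played by the ring from that of the amine.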